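The source may report more compounds than this note shows. Statements on the series, on what has been measured and on what is new or still open speak of the compounds shown alone.

Values in an ADME assay (liver) for metabolic stability, with Liver microsome (Homo sapiens) as the target, read by LC-MS, using microsomes and NADPH, with a stated time of 5 min, at 37 degrees C; a higher number here means faster removal of the compound, a lower number slower removal:
- compound 1 `CCn1c([C@@H](C)NS(=O)(=O)c2ccc(C)cc2)nc2ccc(C(F)(F)F)cc21`: > 100 mL.min-1.g-1 (a limit)
- compound 2 `CCn1c([C@@H](C)NS(=O)(=O)c2ccc(CC(C)C)cc2)nc2ccc(C(F)(F)F)cc21`: > 100 mL.min-1.g-1 (a limit)
- compound 3 `CCn1cc(S(=O)(=O)N[C@H](C)c2nc3ccc(C(F)(F)F)cc3n2CC)cn1`: 95 mL.min-1.g-1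

Going by the values given here, compound 3 is the only compound here with a number. The other two sit at the limit of > 100 mL.min-1.g-1 in this assay, at which 2 of the 3 values shown sit.

Compound 4 `CCn1c([C@@H](C)NS(=O)(=O)c2cn(C)c(C)n2)nc2ccc(C(F)(F)F)cc21` has 1,2-dimethyl-1H-imidazol-4-yl in place of 1-ethyl-1H-pyrazol-4-yl on a sulfonyl sulfur.

Two changes of the group on the sulfonyl sulfur have been measured: an at least 1.0-fold lower number from compound 1 to compound 3 (0.02 log units; that floor lies within the scatter) and an at least 1.0-fold lower number from compound 2 to compound 3 (0.02 log units; that floor lies within the scatter). A further step, a step that the two limits leave unreadable from compound 1 to compound 2, has no readable size. None of these exchanges the two groups now in question. With compound 3 at 95 mL.min-1.g-1 as the only anchor, no step beyond the scatter is expected in this assay, and no direction can be firmly set. The step expected is a 1.4-fold lower number from compound 3 to compound 4 (0.13 log units; within the scatter).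

Compound 4 is estimated at 70 mL.min-1.g-1. The estimated range for compound 4 runs from 30 mL.min-1.g-1 to 100 mL.min-1.g-1.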

Compound 4, intrinsic clearance in microsomes: 43 mL.min-1.g-1
The estimate for compound 4 lay 1.6-fold (0.21 log units) above the measured number, within the range that was stated.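

In this assay, the group on the sulfonyl sulfur now gives a step beyond the scatter: a 2.2-fold lower number from compound 3 to compound 4 (0.34 log units; beyond the scatter). The two groups exchanged have the same atoms joined differently and match in every count computed, so a rearrangement alone separates these compounds, and 1,2-dimethyl-1H-imidazol-4-yl also gives an at least 2.3-fold lower number from compound 2 to compound 4 (0.36 log units; beyond the scatter) and an at least 2.3-fold lower number from compound 1 to compound 4 (0.36 log units; beyond the scatter). Compound 1 and compound 2 each stand at a limit rather than a number, and the step between them cannot be read: the limit of > 100 mL.min-1.g-1 in this assay, at which 2 of the 4 values shown sit.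

The compounds shown do not tell whether the step belongs to the imidazole ring or to its two methyl groups. Also open, on these data alone, is how this assay would respond to 1-methyl-1H-imidazol-4-yl or to an amine on this ring.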